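Aryl swap on the triazole nitrogen: trichlorophenyl analogue

A few compounds are considered here, and "the series" means these few. Any claim that something is new, unique, unknown or untested is made for them only; others in the source may bear on it.

Compound 2 `COc1ccc(OC)c(-n2nncc2CN2C(=O)C3(C(C#N)=C(N)Oc4c(N)cc5nc6ccccc6nc5c43)c3ccccc32)c1` is known only as a limit in a functional assay on HCT-116 cells (Homo sapiens) for antiproliferative activity, read by MTT assay, with a stated time of 48 h (on this read-out higher numbers stand for weaker inhibition and lower numbers for stronger inhibition), where compound 2 gives > 50000 nM. Going by the values given here, its neighbour compound 1 `CCc1ccccc1-n1nncc1CN1C(=O)C2(C(C#N)=C(N)Oc3c(N)cc4nc5ccccc5nc4c32)c2ccccc21` gives 10300 nM in this assay; the single measured step, an at least 4.8-fold higher number from compound 1 to compound 2 (0.68 log units; beyond the scatter), is the only guide, and it rests on (the limit of > 50000 nM in this assay, at which 1 of the 2 values shown sits). Compound 3 `N#CC1=C(N)Oc2c(N)cc3nc4ccccc4nc3c2C12C(=O)N(Cc1cnnn1-c1c(Cl)cc(Cl)cc1Cl)c1ccccc12` differs from compound 2 by 2,4,6-trichlorophenyl in place of 2,5-dimethoxyphenyl on an aromatic nitrogen. Among the compounds with values here, no measured step involves 2,4,6-trichlorophenyl, so the direction is open; a return toward the range of compound 1 is plausible but unproven. Compound 3 is therefore expected near 20000 nM, between 5000 nM and 60000 nM. The estimated step is an at least 2.5-fold lower number from compound 2 to compound 3 (0.39 log units; beyond the scatter).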

Compound 3, half-maximal inhibitory concentration: 12100 nM
Compound 3: middle estimate off by 1.7-fold (0.22 log units), on the high side, and the stated range covers the measured number.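

In this assay, 2,4,6-trichlorophenyl in place of 2,5-dimethoxyphenyl on the aromatic nitrogen gives an at least 4.1-fold lower number from compound 2 to compound 3 (0.61 log units; beyond the scatter), so the weak result of compound 2 does not extend to every substituted phenyl here. Compound 2 gives > 50000 nM, which is a limit and not a number. 2,4,6-Trichlorophenyl and 2-ethylphenyl cannot be told apart at this position, with a 1.2-fold higher number from compound 1 to compound 3 (0.07 log units; within the scatter).

These values do not show what sets compound 2 apart from compound 1 and compound 3. As far as these compounds go, how this position responds to a benzyl group, or to a phenyl bearing an amine or a carboxylic acid, remains open.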